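Amine swap on the carbonyl: compound 3 to compound 4

A few compounds are considered here, and "the series" means these few. Any claim that something is new, unique, unknown or untested is made for them only; others in the source may bear on it.

Values in a functional assay (aorta) with Rattus norvegicus as the target (a higher number here means that more compound is needed for the effect, a lower number that less compound is needed), so far:
- compound 1 `COc1ccc(-c2nc(/N=C(\N)NC3CCCCC3)sc2-c2ccc(OC)cc2)cc1` gives > 100 uM as a limit of the assay, not a number
- compound 2 `COc1ccc(-c2nc(CNC(=O)c3cccnc3)sc2-c2ccc(OC)cc2)cc1` gives 8.2 uM as a number
- compound 3 `COc1ccc(-c2nc(C(=O)N3CCCCC3)sc2-c2ccc(OC)cc2)cc1` gives 11 uM as a number

In this assay compound 3 stands level with compound 2 (a 1.3-fold higher number from compound 2 to compound 3 (0.13 log units; within the scatter)). Compound 4 `COc1ccc(-c2nc(C(=O)N3CCNC(CCO)C3)sc2-c2ccc(OC)cc2)cc1` keeps the core of compound 3 and differs by 3-(2-hydroxyethyl)piperazin-1-yl in place of piperidin-1-yl on a carbonyl carbon on the carbonyl carbon. Going by the values given here, no measured step changes the piperidin-1-yl group alone. The two large steps, an at least 12-fold lower number from compound 1 to compound 2 (1.08 log units; beyond the scatter) and an at least 9.0-fold lower number from compound 1 to compound 3 (0.95 log units; beyond the scatter), both start at the limit of > 100 uM in this assay, at which 1 of the 3 values shown sits, and replace the whole group on the aromatic carbon, so they bear only weakly on this change. The closer guide is compound 2 and compound 3, which carry different groups on that aromatic carbon yet show a 1.3-fold higher number from compound 2 to compound 3 (0.13 log units; within the scatter) in this assay. No step beyond the scatter is therefore expected. The expected step is a 1.3-fold higher number from compound 3 to compound 4 (0.10 log units; within the scatter) and it remains uncertain. The estimate for compound 4 is 14 uM (expected range 4 uM to 50 uM).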

Compound 4, concentration for half-maximal effect: 9.5 uM
For compound 4 the middle estimate is 1.5-fold (0.17 log units) above the measured one; low and high end bracket the measured number.
By their numbers in this assay, from the lowest: compounds 2, 4 and 3 (each within the scatter of the next). At a limit, above all of these: compound 1.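

In this assay, going by these compounds alone, the first step that alters only the group on the carbonyl carbon reads a 1.2-fold lower number from compound 3 to compound 4 (0.06 log units; within the scatter), so compound 3 and compound 4 stand level. The carbonyl carbon therefore accepts 3-(2-hydroxyethyl)piperazin-1-yl, with 2 hydrogen-bond donors and 2 acceptors, in place of piperidin-1-yl, with neither donors nor acceptors, with no step beyond the scatter. Nothing measured here bears on why these two groups give level values.

The compounds shown leave open whether the 2-hydroxyethyl chain and the second ring nitrogen each matter alone, which a plain piperazin-1-yl would begin to separate. On these data alone, a longer chain in place of 2-hydroxyethyl, or a carboxylic acid at its end, also remains open at this position.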